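Changing the Saturated Ring Arm of Compound 1

A few compounds are considered here, and "the series" means these few. Any claim that something is new, unique, unknown or untested is made for them only; others in the source may bear on it.

Measured so far:
compound 1, `CO[C@H]1CC[C@@H](Nc2cc(NCc3cnccc3C(F)(F)F)ncc2C#N)CC1`: 5000 nM
compound 2, `CN(C)C(=O)[C@H]1CC[C@@H](Nc2cc(NCc3cnccc3C(F)(F)F)ncc2C#N)CC1`: 1800 nM

In an assay on isolated protein for inhibition of protein kinase C delta type (Homo sapiens), read by TR-FRET, with a stated time of 2 h (on this read-out higher numbers stand for weaker inhibition and lower numbers for stronger inhibition), compound 1 gives 5000 nM, the highest of the two numbers and therefore the weaker inhibitor shown; its nearest neighbour is compound 2 with 1800 nM. Going by the values given here, the only measured step, a 2.8-fold lower number from compound 1 to compound 2 (0.44 log units; beyond the scatter), exchanges the group on the saturated ring for a different one and lowers the number modestly.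

Compound 3, `CC1(C)C[C@H](Nc2cc(NCc3cnccc3C(F)(F)F)ncc2C#N)CC[C@H]1O`, differs from compound 1 in one place: 4-hydroxy-3,3-dimethylcyclohexyl in place of 4-methoxycyclohexyl on a nitrogen on an aromatic ring. This is a change of the same cyclohexyl arm, but to a hydroxy group with two methyls rather than to an amide, so the measured step bears on it only loosely. It shows that this arm can be altered and that one alteration helped somewhat. Among the compounds with values here, no step tests a hydroxy group or the two methyls. A small lowering is therefore expected for compound 3, because the comparable change gave a 2.8-fold lower number from compound 1 to compound 2 (0.44 log units; beyond the scatter), but with wide uncertainty. Compound 3 is estimated at 3000 nM, between 1000 nM and 9000 nM, meaning an expected step of a 1.7-fold lower number from compound 1 to compound 3 (0.22 log units; within the scatter).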

Compound 3, half-maximal inhibitory concentration: 2200 nM
Beside the measured number, compound 3's estimate is 1.4-fold (0.13 log units) above it; the measured number falls inside the stated range.
By their numbers in this assay, from the lowest: compounds 2 and 3 (each within the scatter of the next); then compound 1.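

The change to 4-hydroxy-3,3-dimethylcyclohexyl gives a 2.3-fold lower number from compound 1 to compound 3 (0.36 log units; beyond the scatter) in this assay and is the second replacement of the 4-methoxycyclohexyl arm to lower the number, after the dimethylcarbamoyl group of compound 2. Two quite different groups on this ring therefore both move the number the same way, and the values of compound 2 and compound 3 lie within the scatter of each other. Nothing available explains why this lowering occurs.

As far as these compounds go, the hydroxy group and the two methyls enter together in compound 3, so their separate contributions remain unknown. From the compounds shown here alone, it also remains open how an amine or a carboxylic acid on the same ring would read in this assay and whether either would lower the number further.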